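A few compounds are considered here, and "the series" means these few. Any claim that something is new, unique, unknown or untested is made for them only; others in the source may bear on it.

Measured so far:
- Compound 2, `N#C[C@H](CCc1ccccc1)NC(=O)[C@@H](CC(=O)N1CCOCC1)CC1CCCCC1`: 25 nM
- Compound 3, `CN1CCC(C#N)(NC(=O)[C@@H](CC(=O)N2CCOCC2)CC2CCCCC2)CC1`: 177 nM
- Compound 1, `N#C[C@@]1(NC(=O)[C@@H](CC(=O)N2CCOCC2)CC2CCCCC2)CCN(C2CCCC2)C1`: "not determined" (no result reported)

These compounds were tested in an assay on isolated protein for inhibition of cathepsin S (Homo sapiens); on this read-out lower numbers stand for tighter binding and higher numbers for weaker binding. Compound 2 gives 25 nM, and compound 3 gives 177 nM, so compound 3 has the higher of the two numbers, and the gap between compound 2 and compound 3 lies beyond the usual scatter of repeated measurements. Compound 1, `N#C[C@@]1(NC(=O)[C@@H](CC(=O)N2CCOCC2)CC2CCCCC2)CCN(C2CCCC2)C1`, belongs to the same series but has no value in this assay, so it cannot help to place compound 3 further.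

Compound 4, `CN1CC[C@@](C#N)(NC(=O)[C@@H](CC(=O)N2CCOCC2)CC2CCCCC2)C1`, has not been measured. It differs from compound 3 in one place: 3-cyano-1-methylpyrrolidin-3-yl in place of 4-cyano-1-methylpiperidin-4-yl on an amide-type nitrogen. The ring that carries the nitrile and the amide nitrogen shrinks by one member and gains a defined stereocentre, while the methyl on the ring nitrogen and everything else stay the same. Going by the values given here, no step between two measured compounds shows what such a change does here, and compound 1, the only other compound with the smaller ring, gives no number. The expectation is therefore cautious: a step of size a 1.5-fold lower number from compound 3 to compound 4 (0.17 log units; within the scatter) from compound 3 to compound 4, within or only slightly beyond the scatter, with no firm direction. Compound 4 is estimated at 120 nM in this assay, in the range 30 nM to 500 nM.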

Compound 4, dissociation constant: 161 nM
Estimate against measurement, compound 4: 1.3-fold (0.13 log units) below, within the range that was stated.
By their numbers in this assay, from the lowest: compound 2; then compounds 4 and 3 (each within the scatter of the next).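

In this assay, placing 3-cyano-1-methylpyrrolidin-3-yl in place of 4-cyano-1-methylpiperidin-4-yl on the amide-type nitrogen gives a 1.1-fold lower number from compound 3 to compound 4 (0.04 log units; within the scatter), so this read-out does not separate the two groups. This is the only pair shown that differs in one place, and it gives the first direct reading at this position: the five-membered non-aromatic ring with its defined stereocentre and the six-membered non-aromatic ring give values within the scatter of each other, with the nitrile and the methyl on the ring nitrogen kept. No measurement shown here bears on why the two groups read alike.

The compounds shown leave open whether the opposite arrangement at the stereocentre of the five-membered ring would give a similar value. They also leave open how other groups on the ring nitrogen, such as an ethyl or an acetyl group, would read, since compound 1, with a cyclopentyl group there, offers no number for comparison.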